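A few compounds are considered here, and "the series" means these few. Any claim that something is new, unique, unknown or untested is made for them only; others in the source may bear on it.

Compound 2 `CN(C(=O)NC(=O)c1ccc(C(F)(F)F)cc1)c1nc(C(F)(F)F)c(C(=O)N/N=C/c2cccc(C(F)(F)F)c2)s1` is the point of departure. In a functional assay on MCF7 cells (Homo sapiens) for inhibition, read by MTT assay, with a stated time of 72 h (on this read-out lower numbers stand for stronger inhibition and higher numbers for weaker inhibition), compound 2 gives 8.95 ug/mL, the second highest of the three numbers in hand. Compound 1 `CN(C(=O)NC(=O)c1c(F)cccc1F)c1nc(C(F)(F)F)c(C(=O)N/N=C/c2cccc(C(F)(F)F)c2)s1` gives 21.8 ug/mL in this assay, and compound 3 `CN(C(=O)NC(=O)c1ccc(F)c(F)c1)c1nc(C(F)(F)F)c(C(=O)N/N=C/c2cccc(C(F)(F)F)c2)s1` gives 4.15 ug/mL. The steps among them all sit on the carbonyl carbon: a 2.4-fold lower number from compound 1 to compound 2 (0.39 log units; beyond the scatter), a 5.3-fold lower number from compound 1 to compound 3 (0.72 log units; beyond the scatter) and a 2.2-fold lower number from compound 2 to compound 3 (0.33 log units; beyond the scatter). Compound 4 `CN(C(=O)NC(=O)c1ccc(C(F)(F)F)cc1)c1nc(C(F)(F)F)c(C(=O)N/N=C/c2ccccc2C(F)(F)F)s1` differs from compound 2 elsewhere: 2-(trifluoromethyl)phenyl in place of 3-(trifluoromethyl)phenyl on a carbon with a double bond to nitrogen. For the measured compounds named here, none of the measured steps touches that carbon, so no step bears directly on the change; the three steps only show that swapping one fluorinated phenyl for another has moved this assay by modest amounts. A step of similar size is therefore expected at most, with no sure direction, and a result within the scatter would not surprise. Compound 4 is expected to give about 9 ug/mL in this assay, between 3 ug/mL and 27 ug/mL, an expected step of a 1.0-fold higher number from compound 2 to compound 4 (0.00 log units; within the scatter).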

Compound 4, half-maximal inhibitory concentration: 2.21 ug/mL
Estimate against measurement, compound 4: 4.1-fold (0.61 log units) above; the whole stated range lies above it.
By their numbers in this assay, from the lowest: compounds 4 and 3 (each within the scatter of the next); then compound 2; then compound 1.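

In this assay, for the compounds shown here, 2-(trifluoromethyl)phenyl in place of 3-(trifluoromethyl)phenyl on a carbon with a double bond to nitrogen gives a 4.0-fold lower number from compound 2 to compound 4 (0.61 log units; beyond the scatter), so this place, which no earlier step touched, responds to a change that keeps the same atoms and only joins them differently. The number therefore moves with changes at this carbon as well as on the carbonyl carbon, and this step is of a size with those seen there. Nothing at hand accounts for the lower number with 2-(trifluoromethyl)phenyl.

Going by these compounds, it remains open whether 2-(trifluoromethyl)phenyl gives a like step when the carbonyl carbon carries 3,4-difluorophenyl or 2,6-difluorophenyl instead of 4-(trifluoromethyl)phenyl. The compounds shown also leave open how an unsubstituted phenyl, or a phenyl bearing a methoxy group or a nitrile, would read on this carbon.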